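Amide Replaces Amine on the Piperidine Ring

A few compounds are considered here, and "the series" means these few. Any claim that something is new, unique, unknown or untested is made for them only; others in the source may bear on it.

Compound 1 `CCCCCOC(=O)N1CCN(C(=O)[C@H](CCC(=O)O)NC(=O)c2cc(N3CCC(COC)CC3)nc(-c3ccccc3)n2)CC1`: 1.1 L/kg
Compound 2 `CCCCCOC(=O)N1CCN(C(=O)[C@H](CCC(=O)O)NC(=O)c2cc(N3CCC(OCCO)CC3)nc(-c3ccccc3)n2)CC1`: 0.8 L/kg
Compound 3 `CCCCCOC(=O)N1CCN(C(=O)[C@H](CCC(=O)O)NC(=O)c2cc(N3CCC(CNC)CC3)nc(-c3ccccc3)n2)CC1`: 2 L/kg

In an in vivo ADME assay on the whole organism (strain Sprague-Dawley) for pharmacokinetics, with Rattus norvegicus as the target (a lower number here means that more of the compound stays in the plasma, a higher number that more of the compound sits outside the plasma), compound 3 gives the largest of the three numbers; the two steps leading to it are a 1.8-fold higher number from compound 1 to compound 3 (0.26 log units; within the scatter) and a 2.5-fold higher number from compound 2 to compound 3 (0.40 log units; beyond the scatter). Compound 4 `CCCCCOC(=O)N1CCN(C(=O)[C@H](CCC(=O)O)NC(=O)c2cc(N3CCC(C(=O)NCC)CC3)nc(-c3ccccc3)n2)CC1` differs from compound 3 by ethylcarbamoyl in place of (methylamino)methyl on a saturated ring carbon. The two steps that change the group at this same ring carbon, from compound 1 and from compound 2 to compound 3, both moved the number upward, one within the scatter and one modestly beyond it. Reversing the direction of change at that carbon suggests a modest downward step in this assay is expected, a 2.0-fold lower number from compound 3 to compound 4 (0.30 log units; within the scatter), though a result within the scatter would not surprise. Compound 4 is therefore estimated at 1 L/kg, within 0.6 L/kg to 1.7 L/kg.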

Compound 4, volume of distribution at steady state: 0.2 L/kg
Compound 4: middle estimate off by 5.0-fold (0.70 log units), on the high side; the measured number lies below the stated range.
By their numbers in this assay, from the lowest: compound 4; then compounds 2, 1 and 3 (each within the scatter of the next, the first and the last beyond it).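

In this assay, ethylcarbamoyl at this ring carbon gives the lowest number of the four: a 10-fold lower number from compound 3 to compound 4 (1.00 log units; beyond the scatter) and a 4.0-fold lower number from compound 2 to compound 4 (0.60 log units; beyond the scatter) and a 5.5-fold lower number from compound 1 to compound 4 (0.74 log units; beyond the scatter) all lie beyond the scatter. Compound 1, compound 2 and compound 3 had shown much smaller differences, so this position can move the read-out further than they suggested. No measurement here explains the drop. On these data alone, with a single amide, it remains open whether the carbonyl or the ethyl chain matters, and what a methylcarbamoyl group or a carboxylic acid would give at this carbon.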